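The compounds below may be only part of what the source reports. "The series", "measured", "known", "first", "only" and "open" are said of these compounds alone.

Compound 1 `O=C1C[C@H](O[C@H]2O[C@H](CO)[C@@H](O)[C@H](O)[C@@H]2O)CN1` and compound 2 `C[C@@H]1O[C@@H](O[C@H]2CNC(=O)C2)[C@H](O)[C@H](O)[C@H]1O` are close relatives, but how their two cores differ is not broken down here. In a functional assay on RAW264.7 cells (Mus musculus) for inhibition, read by Griess assay, with a stated time of 24 h (on this read-out higher numbers stand for weaker inhibition and lower numbers for stronger inhibition), compound 1 gives 67100 nM, and compound 2 gives 116000 nM; these two numbers lie within the scatter of each other, so no order between them can be read. Compound 3 `O=C1C[C@H](O[C@H]2O[C@H](CO)[C@@H](O)[C@H](O)[C@@H]2O)CN1Cc1ccccc1` differs from compound 1 by one change: benzyl in place of hydrogen on an amide-type nitrogen in a ring. In this assay compound 3 gives 64000 nM, and the step of a 1.0-fold lower number from compound 1 to compound 3 (0.02 log units; within the scatter) left the number where it was. Compound 4 `C[C@@H]1O[C@@H](O[C@@H]2CC(=O)N(Cc3ccccc3)C2)[C@H](O)[C@H](O)[C@H]1O` is the not yet measured partner of compound 2, made by the same kind of change: benzyl in place of hydrogen on an amide-type nitrogen in a ring. The place of the change is described in the same words in both pairs. Because the step of a 1.0-fold lower number from compound 1 to compound 3 (0.02 log units; within the scatter) stayed within the scatter, the expectation for compound 4 is a step of a 1.1-fold lower number from compound 2 to compound 4 (0.02 log units; within the scatter) of a similar size, resting on that single measured pair alone. Compound 4 is therefore expected to give about 110000 nM in this assay, with a plausible range from 50000 nM to 250000 nM.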

Compound 4, half-maximal inhibitory concentration: 56000 nM
Beside the measured number, compound 4's estimate is 2.0-fold (0.29 log units) above it, within the range that was stated.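

In this assay putting benzyl in place of hydrogen on the amide-type nitrogen gives a 2.1-fold lower number from compound 2 to compound 4 (0.32 log units; beyond the scatter) and this modest step lies beyond the usual scatter. Set beside the same change on the other core, the new step cannot be told apart from the earlier one: the same change on two cores in this assay, a 1.0-fold lower number (0.02 log units; within the scatter) from compound 1 to compound 3 and a 2.1-fold lower number (0.32 log units; beyond the scatter) from compound 2 to compound 4, 2.0-fold (0.30 log units) apart, within the scatter of two such steps. Among these compounds, the two pairs are therefore compatible with the change carrying over from one core to the other, but two pairs are too few to fix the size of the step or to show that it would hold on further cores, and only the step on the core of compound 2 lies beyond the scatter.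

The compounds shown carry only hydrogen or benzyl on this nitrogen, so it remains open how a methyl, a longer chain such as phenethyl, or a benzyl group bearing an amine or a carboxylic acid would change the number. From the compounds shown here alone, it also remains open whether any of these groups would give similar steps on both cores.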